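A few compounds are considered here, and "the series" means these few. Any claim that something is new, unique, unknown or untested is made for them only; others in the source may bear on it.

Within the data shown here, compound 2 `CC(=O)OC/C(=C\c1ccc(Cl)cc1)C(=O)c1ccc(Cl)cc1` gives the highest of the two numbers in a functional assay on HeLa cells (Homo sapiens) for inhibition, read by sulforhodamine B assay, with a stated time of 48 h (a lower number here means a stronger inhibitor of growth, a higher number a weaker inhibitor of growth), namely 19000 nM, while compound 1 `CC(=O)OC/C(=C\c1ccc(Cl)cc1)C(=O)c1ccccc1` gives 3200 nM; the only measured step, a 5.9-fold higher number from compound 1 to compound 2 (0.77 log units; beyond the scatter), comes from a chloro in place of hydrogen on an aromatic carbon. Compound 3 `CC(=O)OC/C(=C/c1ccc(Cl)cc1)C(=O)c1ccc(Cl)cc1` differs from compound 2 in a different way: the two compounds have the same atoms and bonds and differ only in configuration as drawn: 1 of 1 stereo elements differ; a double bond is drawn E in compound 2 and Z in compound 3. Among the measured compounds shown here, no measured step alters how a double bond is drawn, so that single step cannot show how large this change will be. Compound 3 is therefore expected to move little, the step of no change at the digits printed from compound 2 to compound 3 (within the scatter) staying within the scatter, with an estimate of 19000 nM and a range from 5000 nM to 80000 nM.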

Compound 3, concentration for 50% growth inhibition: 5700 nM
For compound 3 the middle estimate is 3.3-fold (0.52 log units) above the measured one; measured number inside the range.
By their numbers in this assay, from the lowest: compounds 1 and 3 (each within the scatter of the next); then compound 2.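

Drawing the double bond Z rather than E gives a 3.3-fold lower number from compound 2 to compound 3 (0.52 log units; beyond the scatter) in this assay, so the step lies beyond the scatter even though no atom or bond changes. The earlier step showed only the effect of adding a chloro; this one shows that the arrangement around the double bond also matters in this series. The shift can be tied to configuration alone because of one fact: the fact that compounds 2 and 3 differ only in the configuration as drawn

As far as these compounds go, it remains open whether the same change would have a similar effect in compound 1, which lacks the second chloro. Also open, from the compounds shown here alone, is how an amine or a carboxylic acid in place of a chloro would behave.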